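From bromo to trifluoromethoxy at the assay limit

This account rests on a few compounds, and the source may have more. Where it says the series, first, only, none or still open, it means among the compounds named here.

In an ADME assay on RAW264.7 cells (Mus musculus) for cytotoxicity, read by MTT assay, with a stated time of 24 h, in the presence of a further agent that is not named here (on this read-out higher numbers stand for weaker inhibition and lower numbers for stronger inhibition), compound 3 `COc1cc(OC)c2c(c1)C(C(O)c1ccc(OCc3ccc(Br)cc3)cc1)OC2=O` gives > 40000 nM, which is a limit and not a number. Compound 1 `CCOCCOc1ccc(C(O)C2OC(=O)c3c(OC)cc(OC)cc32)cc1` gives > 40000 nM, also a limit. Compound 2 `COc1cc(OC)c2c(c1)C(C(O)c1ccc(OCc3ccc(Cl)cc3)cc1)OC2=O` gives > 40000 nM, again a limit. Compound 4 `COc1cc(OC)c2c(c1)C(C(O)c1ccc(OCc3ccc(OC(F)(F)F)cc3)cc1)OC2=O` carries trifluoromethoxy in place of bromo on an aromatic carbon, para to a large group: trifluoromethoxy in place of bromo on an aromatic carbon.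

The nearest measured change is bromo in place of chloro, a step that the two limits leave unreadable from compound 2 to compound 3. The two others are a step that the two limits leave unreadable from compound 1 to compound 2 and a step that the two limits leave unreadable from compound 1 to compound 3. None of these has a readable size, and the only firm observation is the limit of > 40000 nM in this assay, at which 3 of the 3 values shown sit. With compound 3 also at that limit, no step beyond the usual scatter is expected in this assay, in either direction. The expected change is a step that the limit leaves unreadable from compound 3 to compound 4. Compound 4 is estimated at 50000 nM, with an expected range from 20000 nM to 100000 nM, and it will most likely be reported as a limit again.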

Compound 4, half-maximal inhibitory concentration: > 40000 nM
Compound 4 gave a limit, no number (the forecaster's own chance of this, stated with the estimate: 85%); the middle value does not contradict the limit.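

In this assay compound 4 gives a limit, as do compound 1, compound 2 and compound 3, so no step among these four compounds can be read: the limit of > 40000 nM in this assay, at which 4 of the 4 values shown sit.

The compounds shown leave open whether trifluoromethoxy, bromo and chloro differ at all in this assay, since none of the four gives a number.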